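The source may report more compounds than this note shows. Statements on the series, on what has been measured and on what is new or still open speak of the compounds shown alone.

Of the compounds shown here, three have been measured in an ADME assay on 184B5 cells (Homo sapiens) for cytotoxicity, read by sulforhodamine B assay, with a stated time of 48 h; a lower number here means a stronger inhibitor of growth, a higher number a weaker inhibitor of growth. Compound 1, `O=C1C(=O)N(CN2CCN(c3ccnc4cc(C(F)(F)F)ccc34)CC2)c2cccc(Cl)c21`, gives 47400 nM. Compound 2, `NC(=S)N/N=C1/C(=O)N(CN2CCN(c3ccnc4cc(Cl)ccc34)CC2)c2cccc(Br)c21`, gives 46400 nM. Compound 3, `NC(=S)N/N=C1/C(=O)N(CN2CCN(c3ccnc4cc(Cl)ccc34)CC2)c2cc(Cl)ccc21`, gives 41300 nM. Compound 3 carries the lowest of the three numbers, but the gaps to compound 2 and to compound 1 both lie within the scatter of repeated measurements, so the three values are indistinguishable on the numbers shown; no ranking among them can be drawn.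

Compound 4, `NC(=S)N/N=C1/C(=O)N(CN2CCN(c3ccnc4cc(Cl)ccc34)CC2)c2cc(Br)ccc21`, is not yet measured. It differs from compound 3 in one place: bromo in place of chloro on an aromatic carbon. For the measured compounds named here, no pair of measured compounds that differs in this single place exists, so there is no measured step to lean on. The exchange of one halogen for another on the same aromatic carbon is a small change in the counted difference, and the three measured values sit close together regardless of their halogen pattern. The expectation for the step from compound 3 to compound 4 is therefore a change of a 1.0-fold higher number from compound 3 to compound 4 (0.01 log units; within the scatter), in no particular direction and not beyond the scatter. Compound 4 is estimated at 42000 nM in this assay, with a range from 21000 nM to 84000 nM.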

Compound 4, concentration for 50% growth inhibition: 13100 nM
For compound 4 the middle estimate is 3.2-fold (0.51 log units) above the measured one; the whole stated range lies above it.
By their numbers in this assay, from the lowest: compound 4; then compounds 3, 2 and 1 (each within the scatter of the next).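

In this assay this position proves sensitive to the halogen it carries: bromo in place of chloro on this aromatic carbon, meta to a fused ring and para to a fused ring, gives (a 3.2-fold lower number from compound 3 to compound 4 (0.50 log units; beyond the scatter)), the first difference in the series that lies beyond the scatter. The earlier values gave no hint of this, and the lower number does not follow bromo alone: compound 2 also carries bromo, at another place on the shared core, and gives (46400 nM), whereas compound 4 gives (13100 nM). Nothing at hand explains why this exchange moves the number.

As far as these compounds go, the finding rests on a single pair, so it remains open whether the number keeps falling, holds or rises with iodo, fluoro, methyl or methoxy on the same aromatic carbon. From the compounds shown here alone, it is also open whether bromo in place of chloro on this carbon gives a comparable step on another core, such as one carrying a trifluoromethyl group in place of the other chloro.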